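This account rests on a few compounds, and the source may have more. Where it says the series, first, only, none or still open, it means among the compounds named here.

Of the compounds shown here, two of one series have so far been tested in a functional assay on HCT-116 cells (Homo sapiens) for cytotoxicity, read by MTT assay, with a stated time of 72 h; on this read-out lower numbers stand for stronger inhibition and higher numbers for weaker inhibition. Compound 1 `NCCCNc1c(C(=O)NCc2ccc(F)cc2)nc(Br)c2cccnc12` gives 18000 nM, the highest of the two numbers. Compound 2 `N[C@H]1CC[C@H](Nc2c(C(=O)NCc3ccc(F)cc3)nc(N3CCCCC3)c3cccnc23)CC1` gives 8500 nM in this assay, a gap that lies beyond the usual scatter. Compound 3 `O=C(NCc1ccc(F)cc1)c1nc(Br)c2cccnc2c1N1CCNCC1` awaits measurement in this assay; it differs from compound 1 by piperazin-1-yl in place of (3-aminopropyl)amino on an aromatic carbon. Going by the values given here, no measured pair differs in only one place, so nothing shows how such a change shifts the numbers. The change is expected to be small, a 1.5-fold lower number from compound 1 to compound 3 (0.18 log units; within the scatter), with no clear direction beyond the scatter. Compound 3 is estimated at 12000 nM, within 4000 nM to 40000 nM.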

Compound 3, half-maximal inhibitory concentration: > 10000 nM
Compound 3: a limit, no number; the forecaster's own chance of this, stated with the estimate: 10%; the middle value is on the limit's open side.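

Going by these compounds alone, the value of compound 3, > 10000 nM, is a limit and not a number, and no step from compound 1 to compound 3 can be read from it. Going by these compounds, whether piperazin-1-yl in place of (3-aminopropyl)amino shifts the number, and in which direction, stays open.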